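The source may report more compounds than this note shows. Statements on the series, on what has been measured and on what is new or still open speak of the compounds shown alone.

Among the measured compounds shown here, compound 1 `COc1ccccc1-n1cc(COc2c(/C=C\C(=O)O)ccc(OC)c2CC=C(C)C)nn1` holds the higher of the two numbers recorded, though the gap to its only measured neighbour lies within the scatter; in a functional assay on HCT-116 cells (Homo sapiens) for cytotoxicity, read by MTT assay, with a stated time of 24 h (on this read-out lower numbers stand for stronger inhibition and higher numbers for weaker inhibition), compound 1 gives 32200 nM. For the measured compounds named here, compound 2 `COc1ccc(/C=C\C(=O)O)c(OCc2cn(-c3ccc(NC(=O)c4ccccc4)cc3)nn2)c1CC=C(C)C` shares the core, and in this assay compound 2 gives 16400 nM, a number within the scatter of the one for compound 1, so no order can be read between the two. Compound 3 `COc1ccc(/C=C\C(=O)O)c(OCc2cn(-c3ccccc3F)nn2)c1CC=C(C)C` carries no result in this assay: for compound 3 the entry reads "not determined" (no result reported). Compound 4 `COc1ccc(/C=C\C(=O)O)c(OCc2cn(-c3cccc(C#N)c3)nn2)c1CC=C(C)C` is reached from compound 1 by a single change: 3-cyanophenyl in place of 2-methoxyphenyl on an aromatic nitrogen. Going by the values given here, no step between two measured compounds of this set involves this exchange, so there is no direct guide to its size or direction. The two numbers that exist sit close together, and nothing in the data shows that a change of this kind moves the read-out beyond the scatter. The step of a 1.3-fold lower number from compound 1 to compound 4 (0.11 log units; within the scatter) is therefore expected to stay within the scatter. The estimate for compound 4 in this assay is 25000 nM, with a range from 8000 nM to 80000 nM.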

Compound 4, half-maximal inhibitory concentration: 35300 nM
Estimate against measurement, compound 4: 1.4-fold (0.15 log units) below; measured number inside the range.
By their numbers in this assay, from the lowest: compounds 2, 1 and 4 (each within the scatter of the next, the first and the last beyond it).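

In this assay, among the compounds shown here, 3-cyanophenyl in place of 2-methoxyphenyl on an aromatic nitrogen gives a 1.1-fold higher number from compound 1 to compound 4 (0.04 log units; within the scatter), the only measured step of this set at this position. This exchange therefore leaves the read-out within the scatter, so these two aryl groups cannot be told apart here, and because the step alters both the substituent and its place on the phenyl ring, neither can be judged alone. No measurement shown bears on the reason for this result.

As far as these compounds go, it remains open whether an unsubstituted phenyl, an aminophenyl or a simple alkyl chain on this nitrogen would move the number beyond the scatter. The rest of the shared core is the same in all compounds shown, so how the read-out responds to changes there also remains open.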